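Removing the chloro group: expected inhibition of compound 3

A few compounds are considered here, and "the series" means these few. Any claim that something is new, unique, unknown or untested is made for them only; others in the source may bear on it.

Measured so far:
compound 1, `Clc1ccc(-c2nc3ncccc3o2)cc1`: 24%
compound 2, `Clc1cccc(-c2nc3ncccc3o2)c1`: 32%

In a functional assay on the whole organism for inhibition, with Rattus norvegicus as the target, at a dose of 30 mg/kg (a higher number here means more inhibition at the dose given (going by the name of the read-out), a lower number less inhibition), compound 2 gives 32%, the top number of the two, while compound 1 gives 24%. For the measured compounds named here, the gap between them lies within the usual scatter of repeated measurements, so the two compounds cannot be told apart on these numbers, and no step between measured compounds has been worked out.

Compound 3, `c1ccc(-c2nc3ncccc3o2)cc1`, keeps the shared core of compound 2 but carries the change (hydrogen in place of chloro on an aromatic carbon). As far as these compounds go, both measured compounds carry a chloro group and both show modest inhibition; whether the chloro group matters is unknown from these data. A small downward step is expected, a number 10 percentage points lower from compound 2 to compound 3 (within the scatter), not clearly beyond the scatter. The estimated value for compound 3 in this assay is 22%, with a range from 5% to 40%.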

Compound 3, a percentage reported as inhibition, in the whole organism at one dose (the size of the read-out at that dose, not a potency): 41%
For compound 3 the middle estimate is 19 percentage points below the measured one, outside the stated range (above it).
By their numbers in this assay, from the lowest: compounds 1, 2 and 3 (each within the scatter of the next, the first and the last beyond it).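

Measured in this assay the swap of chloro for hydrogen on the aromatic carbon gives a number 9 percentage points higher from compound 2 to compound 3 (within the scatter) so at this place the two compounds cannot be told apart. For the compounds shown here, the same kind of swap gives a number 17 percentage points higher from compound 1 to compound 3 (beyond the scatter) and this is the first gap to clear the scatter, though only modestly. Inhibition at this dose therefore does not depend on a chloro group: the shared core with a bare ring keeps it.

As far as these compounds go, what a different group on this ring, such as a methoxy group or an amine, would do remains open. Nothing measured here gives a reason for these steps.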